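Chain extension of a hydroxyalkyl arm on macrocyclic ureas

The compounds below may be only part of what the source reports. "The series", "measured", "known", "first", "only" and "open" are said of these compounds alone.

Measured compounds:
Compound 1 `N#Cc1ncc2nc1OCC/C=C\COc1ccc(CCO)cc1NC(=O)N2` gives > 10000 nM.
Compound 2 `N#Cc1ncc2nc1OCC/C=C\COc1ccc(CCCO)cc1NC(=O)N2` gives > 10000 nM.
Compound 3 `N#Cc1ncc2nc1OCCCCCOc1ccc(CCO)cc1NC(=O)N2` gives > 10000 nM.

Three macrocyclic ureas have been tested in a functional assay on NCI-H1299 cells (Homo sapiens), read by flow cytometry; on this read-out higher numbers stand for an effect only at larger amounts of compound and lower numbers for an effect already at smaller amounts. Each value above is a limit of the assay, not a number; the compounds simply showed no effect up to that concentration. The result is summed up by the limit of > 10000 nM in this assay, at which 3 of the 3 values shown sit.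

Compound 1 and compound 2 differ in a single place: hydroxymethyl in place of hydroxy on a saturated chain carbon, two bonds along the chain from an aromatic carbon. Because both values are limits, the step that the two limits leave unreadable from compound 1 to compound 2 cannot be read; it is only known that neither compound reached an effect within the tested range.

Compound 4 `N#Cc1ncc2nc1OCCCCCOc1ccc(CCCO)cc1NC(=O)N2` has not yet been measured. It is related to compound 3 by the same change that links compound 1 to compound 2: hydroxymethyl in place of hydroxy on a saturated chain carbon, two bonds along the chain from an aromatic carbon. The place of the change is the same in both pairs. How the core of compound 3 differs from the core of compound 1 is not broken down here; the two cores differ in more than one place, and compound 3 is also only known through its limit.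

With every measured neighbour sitting at the limit, the step that the limit leaves unreadable from compound 3 to compound 4 is expected to be unreadable in the same way, and compound 4 is estimated at 20000 nM in this assay, within a range from 8000 nM to 60000 nM, most likely reported again as a limit.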

Compound 4, half-maximal effective concentration: > 10000 nM
Compound 4: a limit, no number; the forecaster's own chance of this, stated with the estimate: 85%; the middle value is on the limit's open side.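

Compound 3 and compound 4 each give a limit of the assay rather than a number, and the step between them cannot be read. The picture for the series stays as it was: the limit of > 10000 nM in this assay, at which 4 of the 4 values shown sit. Left open is whether the change from hydroxy to hydroxymethyl, or the difference between the cores, matters at all in this assay, and at what concentration any of these compounds would begin to act.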